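This account rests on a few compounds, and the source may have more. Where it says the series, first, only, none or still open, it means among the compounds named here.

Compound 1 `COc1cc(N2C(N)=C(C#N)C(c3c(OC)ccc4ccccc34)C3=C2CC(C)(C)CC3=O)cc(OC)c1OC` and compound 2 `COc1cc(N2C(N)=C(C#N)C(c3cccc([N+](=O)[O-])c3)C3=C2CC(C)(C)CC3=O)cc(OC)c1OC` share one core and differ only in the group carried on the saturated ring carbon. In a functional assay on Ehrlich cells (Mus musculus) for cytotoxicity, tested at 10 ug/mL (a lower number here means a weaker effect, a higher number a stronger effect of the compound at the concentration tested), compound 1 gives 0%, and in this assay compound 2 gives 5%. Among the measured compounds shown here, the single measured step, a number 5 percentage points higher from compound 1 to compound 2 (within the scatter), does not separate the two compounds, so neither stands apart from the other on the numbers so far; both sit at the bottom of the read-out.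

Compound 3 `COc1cc(N2C(N)=C(C#N)C(c3ccc(C)cc3)C3=C2CC(C)(C)CC3=O)cc(OC)c1OC` is the next member of the series. Its change from compound 2 is 4-methylphenyl in place of 3-nitrophenyl on a saturated ring carbon. For the measured compounds named here, the only step that bears on this place is a number 5 percentage points higher from compound 1 to compound 2 (within the scatter), which exchanged one group for another at the same saturated ring carbon without moving the number beyond the scatter. Nothing in the series links the group at this position to a shift in this assay. For compound 3 no step beyond the scatter is therefore expected, and the estimated change is a number 2 percentage points lower from compound 2 to compound 3 (within the scatter). Compound 3 is expected to give 3% in this assay, within an estimated range from 0% to 15%.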

Compound 3, a percentage reported as activity, at one concentration (the size of the read-out at that concentration, not a potency): 30%
The estimate for compound 3 lay 27 percentage points below the measured number, outside the stated range (above it).
By their numbers in this assay, from the lowest: compounds 1 and 2 (each within the scatter of the next); then compound 3.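

In this assay, the group on the saturated ring carbon proves able to move the read-out: exchanging 3-nitrophenyl for 4-methylphenyl gives a number 25 percentage points higher from compound 2 to compound 3 (beyond the scatter) and exchanging 2-methoxynaphthalen-1-yl for 4-methylphenyl gives a number 30 percentage points higher from compound 1 to compound 3 (beyond the scatter) in the same series. Among the compounds shown here, the earlier impression of a silent position therefore held only for the pair compound 1 and compound 2, and 4-methylphenyl is the only one of the three groups that stands apart on the numbers. Nothing available here accounts for the rise, and no measurement bears on what the 4-methylphenyl group does at this carbon.

The two steps replace the whole aryl group, so the shown compounds cannot separate the effect of the methyl group from that of the rest of the exchange, and a plain phenyl, a 4-ethylphenyl or a 4-methoxyphenyl at the same carbon would begin to settle that. Going by these compounds, with compound 3 at 30% at a single concentration, it also remains open whether this read-out reflects a usable potency or only a modest effect at that concentration.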